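The compounds below may be only part of what the source reports. "The series", "measured", "known", "first", "only" and "open" are said of these compounds alone.

Compound 1 `O=C(O)CCc1ccc(C#CC2CC2)cc1`, compound 2 `O=C(O)CCc1ccc(C#CCc2ccccc2)cc1` and compound 3 `O=C(O)CCc1ccc(C#CC2CCCCC2)cc1` share one core and differ only in the group carried on the triple-bonded carbon. In a functional assay on 1321-N1 cells for agonist activity at Free fatty acid receptor 1 (Homo sapiens), read by calcium flux, with a stated time of 0.4 s (on this read-out higher numbers stand for an effect only at larger amounts of compound and lower numbers for an effect already at smaller amounts), compound 1 gives 5010 nM, compound 2 gives 389 nM and compound 3 gives 513 nM. Compound 2 stands at the low end of these numbers, yet its gap to compound 3 lies within the scatter, so the two cannot be ranked; only its gap to compound 1 lies beyond it. Among the compounds with values here, the single step among the three, a 9.8-fold lower number from compound 1 to compound 3 (0.99 log units; beyond the scatter), shows that replacing the saturated ring on the triple-bonded carbon shifted the number well past the scatter.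

Compound 4 `O=C(O)CCc1ccc(C#CCCc2ccccc2)cc1` has not yet been measured in this assay. It differs from compound 2 by benzyl in place of phenyl on a saturated chain carbon bound to a triple-bonded carbon. Within the data shown here, no measured step alters the chain in this way; the step from compound 1 to compound 3 concerns the ring on the triple-bonded carbon and bears on it only loosely. The closeness of compound 2 and compound 3, which carry two unrelated groups at that position, suggests that variation there is tolerated. The expected step of a 1.3-fold higher number from compound 2 to compound 4 (0.11 log units; within the scatter) is therefore one that stays within the scatter or moves only modestly. Compound 4 is estimated at 500 nM, with a range from 150 nM to 2000 nM.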

Compound 4, half-maximal effective concentration: 1820 nM
Compound 4: the middle estimate sits 3.6-fold (0.56 log units) below what was measured; measured number inside the range.
By their numbers in this assay, from the lowest: compounds 2 and 3 (each within the scatter of the next); then compound 4; then compound 1.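

Within the data shown here, the step of a 4.7-fold higher number from compound 2 to compound 4 (0.67 log units; beyond the scatter) in this assay is the first measured change on a saturated chain carbon bound to a triple-bonded carbon, and it shows that this position does respond to a small change in the group it carries. Phenyl, with 6 heavy atoms, gives way to benzyl, with 7 heavy atoms, while the single six-membered aromatic ring, the absence of hydrogen-bond donors and acceptors, and the lack of net charge all stay the same, so a shift beyond the scatter came with one added carbon and no change in any of these counts. No measurement available here explains why this change moves the number.

The compounds shown leave open whether a still longer chain, such as a three-carbon link ending in phenyl, would move the number further in the same direction or whether the effect stops at benzyl. They also leave open how an oxygen atom in the chain, or a fluorine or methoxy group on the phenyl ring, would behave at this position.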